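The source may hold more compounds than are shown below. What is called first, only, known or untested is meant among the compounds shown, and "the series" means these compounds.

Measured in an assay on isolated protein with Bile acid receptor (Homo sapiens) as the target; on this read-out higher numbers stand for an effect only at larger amounts of compound and lower numbers for an effect already at smaller amounts:
compound 1 `COC(=O)/C=C/c1cccc(N(Cc2ccc(/C=C/c3ccccn3)cc2)C(=O)C2CCCCC2)c1`, 309 nM;
compound 2 `COC(=O)/C=C/c1cccc(N(Cc2ccc(-c3ccc(F)c(F)c3)cc2)C(=O)C2CCCCC2)c1`, 72 nM;
compound 3 `COC(=O)/C=C/c1cccc(N(Cc2ccc(-c3ccc(SC)cc3)cc2)C(=O)C2CCCCC2)c1`, 69 nM.

Compound 3 gives the smallest number of the three, yet a 1.0-fold lower number from compound 2 to compound 3 (0.02 log units; within the scatter), so compounds 2 and 3 cannot be told apart, while a 4.5-fold lower number from compound 1 to compound 3 (0.65 log units; beyond the scatter). Compound 4 `COC(=O)/C=C/c1cccc(N(Cc2ccc(-c3cccc(OC(F)(F)F)c3)cc2)C(=O)C2CCCCC2)c1` carries 3-(trifluoromethoxy)phenyl in place of 4-(methylsulfanyl)phenyl on an aromatic carbon. The step that bears most directly on this is the swap of one substituted phenyl for another, in which a 1.0-fold lower number from compound 2 to compound 3 (0.02 log units; within the scatter); the larger steps, a 4.3-fold lower number from compound 1 to compound 2 (0.63 log units; beyond the scatter) and a 4.5-fold lower number from compound 1 to compound 3 (0.65 log units; beyond the scatter), both start from a different kind of group and say little here. The expected outcome for compound 4 is therefore a change no larger than the scatter, a 1.2-fold higher number from compound 3 to compound 4 (0.06 log units; within the scatter), in this assay. Compound 4 is estimated at 80 nM, with a range from 30 nM to 250 nM.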

Compound 4, half-maximal effective concentration: 420 nM
Beside the measured number, compound 4's estimate is 5.3-fold (0.72 log units) below it, and the stated range ends below it.
By their numbers in this assay, from the lowest: compounds 3 and 2 (each within the scatter of the next); then compounds 1 and 4 (each within the scatter of the next).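

With 3-(trifluoromethoxy)phenyl at this position, substituted phenyl groups no longer read alike: the change gives a 6.1-fold higher number from compound 3 to compound 4 (0.78 log units; beyond the scatter) and a 5.8-fold higher number from compound 2 to compound 4 (0.77 log units; beyond the scatter), although compound 2 and compound 3 had shown no separation. A phenyl group alone therefore does not secure the lower numbers, as a 1.4-fold higher number from compound 1 to compound 4 (0.13 log units; within the scatter) places compound 4 within the scatter of the 2-(pyridin-2-yl)ethenyl compound. No supporting data explain this shift. The compounds shown leave open whether the trifluoromethoxy group or its place on the phenyl ring drives the step, and how a phenyl carrying an amine or a carboxylic acid would read.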